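Moving from a pyrrolidine to a methylpiperidine on the amide

The source may hold more compounds than are shown below. What is called first, only, known or untested is meant among the compounds shown, and "the series" means these compounds.

Of the compounds shown here, three that share one core have so far been measured in an ADME assay on cells (Hepatocyte, Rattus norvegicus) for metabolic stability; on this read-out higher numbers stand for fast clearance and lower numbers for slow clearance. Compound 1, whose structure is `Cc1ccc2[nH]c(C(=O)N[C@H]3CN(S(=O)(=O)c4cnccn4)C[C@@H]3C(=O)NCCN(C)C)cc2c1`, gives 12 uL/min. Compound 2, with the structure `Cc1ccc2[nH]c(C(=O)N[C@H]3CCN(S(=O)(=O)N(C)C)C[C@@H]3C(=O)NCCN(C)C)cc2c1`, gives 10 uL/min. Compound 3, drawn as `Cc1ccc2[nH]c(C(=O)N[C@H]3CN(S(=O)(=O)c4ccccc4)C[C@@H]3C(=O)NC[C@H]3CCCN3)cc2c1`, gives 10 uL/min in this assay. The numbers for compound 3 and compound 2 agree at the digits shown, and the gap between compound 3 and compound 1 also lies within the usual scatter of such measurements, so none of the three can be set apart from the others on this read-out.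

Compound 4, not yet measured, has the structure `Cc1ccc2[nH]c(C(=O)N[C@H]3CN(S(=O)(=O)c4ccccc4)C[C@@H]3C(=O)N[C@@H]3CCCN(C)C3)cc2c1`. It differs from compound 3 in a single place: 1-methylpiperidin-3-yl in place of (pyrrolidin-2-yl)methyl on an amide-type nitrogen. Within the data shown here, no pair of measured compounds shows this kind of change, so its effect can only be guessed.

With every measured value so close together, the step from compound 3 to compound 4 is expected to be small, a 1.4-fold higher number from compound 3 to compound 4 (0.15 log units; within the scatter), and probably no larger than the scatter itself. On that basis compound 4 is estimated to give 14 uL/min in this assay, with a likely range from 7 uL/min to 28 uL/min.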

Compound 4, intrinsic clearance in a liver preparation (reported as CLH), per the amount of preparation that the assay uses: 23 uL/min
For compound 4 the middle estimate is 1.6-fold (0.22 log units) below the measured one, within the range that was stated.
By their numbers in this assay, from the lowest: compounds 2, 3, 1 and 4 (each within the scatter of the next, the first and the last beyond it).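

In this assay, among these compounds, this is the first change that can be read on its own, and it clears the scatter: putting 1-methylpiperidin-3-yl in place of (pyrrolidin-2-yl)methyl on the amide-type nitrogen gives a 2.3-fold higher number from compound 3 to compound 4 (0.36 log units; beyond the scatter). Among the compounds shown here, the result shows that clearance responds to this amide substituent while the rest of the molecule stays the same, although the close values of the earlier compounds gave no sign of that. The swap alters several features at once, as a five-membered ring becomes a six-membered ring and the entering group has no hydrogen-bond donor where the leaving group has one, and no measurement here explains the step.

The compounds shown cannot separate these features, so it remains open whether the rise follows the ring size, the methyl on the ring nitrogen or the change in how the ring is attached to the amide. A plain piperidin-3-yl group or a (1-methylpyrrolidin-2-yl)methyl group at the same place would help to tell these possibilities apart.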